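The source may hold more compounds than are shown below. What is called first, only, known or untested is meant among the compounds shown, and "the series" means these compounds.

Compound 1 `c1ccc(CNC(c2ccc[nH]2)c2nnc(-c3ccccc3)o2)cc1` is the weakest of the three measured compounds in a functional assay on HT-29 cells (Homo sapiens) for cytotoxicity, read by MTT assay, with a stated time of 24 h (on this read-out higher numbers stand for weaker inhibition and lower numbers for stronger inhibition), where compound 1 gives 198000 nM. Two single-point changes to it have been measured. Compound 2 `Clc1cccc(-c2nnc(C(NCc3ccccc3)c3ccc[nH]3)o2)c1` gives 48300 nM in this assay, which is a 4.1-fold lower number from compound 1 to compound 2 (0.61 log units; beyond the scatter). Compound 3 `Clc1ccc(-c2nnc(C(NCc3ccccc3)c3ccc[nH]3)o2)cc1` gives 54500 nM, which is a 3.6-fold lower number from compound 1 to compound 3 (0.56 log units; beyond the scatter). Between those two, a 1.1-fold higher number from compound 2 to compound 3 (0.05 log units; within the scatter), so the two ring positions are not told apart on these numbers. Compound 4 `Cc1ccc(-c2nnc(C(NCc3ccccc3)c3ccc[nH]3)o2)cc1` differs from compound 1 by methyl in place of hydrogen on an aromatic carbon, read one bond further out as phenyl to 4-methylphenyl. Within the data shown here, no methyl step has been measured; the two chloro steps are the nearest guides, and both lowered the number by a modest margin that lay beyond the scatter. Methyl is a different group from chloro, and the data give no measured ground for assuming it repeats that margin in full, so a smaller step in the same direction is the cautious reading. Compound 4 is expected to take such a step, a 2.2-fold lower number from compound 1 to compound 4 (0.34 log units; beyond the scatter). Compound 4 is therefore estimated at 90000 nM in this assay, with a range from 40000 nM to 200000 nM.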

Compound 4, half-maximal inhibitory concentration: 249000 nM
Compound 4: middle estimate off by 2.8-fold (0.44 log units), on the low side; the whole stated range lies below it.
By their numbers in this assay, from the lowest: compounds 2 and 3 (each within the scatter of the next); then compounds 1 and 4 (each within the scatter of the next).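

In this assay the methyl step reads a 1.3-fold higher number from compound 1 to compound 4 (0.10 log units; within the scatter), so at this place on the phenyl ring, para to a large group, 4-methylphenyl is not told apart from phenyl. Methyl and chloro do part at the same position, with a 4.6-fold higher number from compound 3 to compound 4 (0.66 log units; beyond the scatter), and the 3-chlorophenyl compound shows a similar gap, with a 5.2-fold higher number from compound 2 to compound 4 (0.71 log units; beyond the scatter). The lower numbers of compound 2 and compound 3 therefore do not extend to every group placed on this ring, since among these four compounds only the two chloro compounds stand clear of compound 1, and compound 4 goes against any such general pattern; no measurement given here accounts for this difference between chloro and methyl.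

The compounds shown leave open whether a fluoro, a bromo or a methoxy group at this position would fall with the chloro compounds or with compound 4. They also leave open how an amine or a carboxylic acid would read on the same ring, and whether methyl would give the same result at another position on it.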